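A few compounds are considered here, and "the series" means these few. Any claim that something is new, unique, unknown or untested is made for them only; others in the source may bear on it.

Compound 1 `Cc1nnc(NC(N)=O)cc1Cc1ccccc1` gives 10.2 mg/kg in a functional assay on the whole organism with Mus musculus as the target, in the maximal electroshock model; a higher number here means that more compound is needed for the effect, a lower number that less compound is needed. Compound 2 `Cc1nn2c(C)nnc2cc1Cc1ccccc1` gives 26 mg/kg in this assay. Compound 3 `Cc1nn2c(C)nnc2cc1Cc1ccccc1Cl` gives 30.5 mg/kg in this assay.

Among these three, compound 3 carries the highest number, but its gap to compound 2 is within the scatter: a 1.2-fold higher number from compound 2 to compound 3 (0.07 log units; within the scatter). Going by the values given here, compound 1, by contrast, gives a number that is lower than that of compound 3 by more than the scatter, and no single-point step connects these two compounds.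

Compound 4 `Cc1nn2c(N)nnc2cc1Cc1ccccc1Cl` differs from compound 3 by a single change: amino in place of methyl on an aromatic carbon. Among the compounds with values here, none of the measured steps covers an exchange of this kind; the only measured step, from compound 2 to compound 3, replaces hydrogen with chloro on the benzyl ring and stays within the scatter. There is therefore no direct basis for expecting movement in either direction, and compound 4 is expected to stay within the scatter of compound 3, with the step of a 1.4-fold lower number from compound 3 to compound 4 (0.14 log units; within the scatter) reflecting that expectation. Compound 4 is thus estimated at 22 mg/kg, within a range of 9 mg/kg to 55 mg/kg.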

Compound 4, dose for half-maximal effect: 17.4 mg/kg
Compound 4: the middle estimate sits 1.3-fold (0.10 log units) above what was measured, and the stated range covers the measured number.
By their numbers in this assay, from the lowest: compounds 1, 4, 2 and 3 (each within the scatter of the next, the first and the last beyond it).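

In this assay, amino in place of methyl on an aromatic carbon of the five-membered aromatic ring with 3 nitrogen, between two ring nitrogen atoms, gives a 1.8-fold lower number from compound 3 to compound 4 (0.24 log units; within the scatter), so this position accepts the exchange within the scatter even though the amino group adds a hydrogen-bond donor and a hydrogen-bond acceptor. Going by these compounds alone, the one earlier step, a 1.2-fold higher number from compound 2 to compound 3 (0.07 log units; within the scatter), lay elsewhere in the molecule, and compound 2 and compound 3 both carry methyl here, so they gave no reading of this position. Nothing measured here offers an explanation of this result.

From the compounds shown here alone, it remains open whether a longer chain such as ethyl, a dimethylamino group or a hydroxyl group at this position would also stay within the scatter of compound 3. Going by these compounds, it is equally open whether amino in place of methyl reads the same way on the core of compound 2, without the chloro.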